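The compounds below may be only part of what the source reports. "The series", "measured", "known", "first", "only" and "open" are said of these compounds alone.

Measured compounds:
compound 1 `OC[C@H]1O[C@@H](n2cnc3c(NCc4ccc(F)cc4)ncnc32)[C@H](O)[C@@H]1O`: 44300 nM
compound 2 `OC[C@H]1O[C@@H](n2cnc3c(NCc4cccc(Br)c4)ncnc32)[C@H](O)[C@@H]1O`: a limit, > 166000 nM
compound 3 `Cc1ccc(CNc2ncnc3c2ncn3[C@@H]2O[C@H](CO)[C@@H](O)[C@H]2O)cc1`: a limit, > 166000 nM

Going by the values given here, in an ADME assay on NIH3T3 cells (Mus musculus) for cytotoxicity, with a stated time of 72 h (on this read-out lower numbers stand for stronger inhibition and higher numbers for weaker inhibition), compound 1 gives the only actual number of the set, 44300 nM. Compound 2 reaches only a limit of the assay, > 166000 nM. Compound 3 likewise reaches only a limit, > 166000 nM. Hence (the limit of > 166000 nM in this assay, at which 2 of the 3 values shown sit). The two readable steps both move away from compound 1 toward that limit: an at least 3.7-fold higher number from compound 1 to compound 2 (0.57 log units; beyond the scatter) and an at least 3.7-fold higher number from compound 1 to compound 3 (0.57 log units; beyond the scatter). Between the two limit compounds, a step that the two limits leave unreadable from compound 2 to compound 3.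

Compound 4 `OC[C@H]1O[C@@H](n2cnc3c(NCc4ccc(F)c(Cl)c4)ncnc32)[C@H](O)[C@@H]1O` differs from compound 1 by chloro in place of hydrogen on an aromatic carbon. Among the compounds with values here, no measured step adds a group to the 4-fluorophenyl; the two changes that alter this ring both raise the number at least modestly. A modest rise is therefore expected, a 1.6-fold higher number from compound 1 to compound 4 (0.20 log units; within the scatter). For compound 4 the estimate is 70000 nM, within 22000 nM to 166000 nM.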

Compound 4, half-maximal inhibitory concentration: > 166000 nM
Compound 4: only a limit was reported; the forecaster's own chance of this, stated with the estimate: 35%; at least 2.3-fold (0.37 log units) between middle value and limit.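

Chloro in place of hydrogen on the 4-fluorophenyl ring of compound 1, ortho to the fluoro group, gives an at least 3.7-fold higher number from compound 1 to compound 4 (0.57 log units; beyond the scatter) in this assay. Retaining the fluoro group therefore does not preserve the measured value of compound 1 once this chloro enters. The steps among compound 2, compound 3 and compound 4 cannot be read, and compound 1 remains the only actual number in the set: the limit of > 166000 nM in this assay, at which 3 of the 4 values shown sit.

On these data alone, whether a hydroxyl or an amine on this aromatic carbon would give a value under that limit stays open.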